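Indolyl-hydrazone benzothiazolyl ureas: effect of removing the N-benzyl group

A few compounds are considered here, and "the series" means these few. Any claim that something is new, unique, unknown or untested is made for them only; others in the source may bear on it.

Measured compounds:
compound 1 `CCN(CC)Cc1ccc2nc(NC(=O)N/N=C/c3cn(Cc4ccccc4Cl)c4ccccc34)sc2c1`: 980 nM
compound 2 `CC1CCN(Cc2ccc3nc(NC(=O)N/N=C/c4cn(Cc5ccccc5Cl)c5ccccc45)sc3c2)CC1`: 1080 nM

In a functional assay on NCI-H460 cells (Homo sapiens) for cytotoxicity, read by MTT assay, with a stated time of 72 h (on this read-out higher numbers stand for weaker inhibition and lower numbers for stronger inhibition), compound 2 gives the higher of the two numbers, yet a 1.1-fold higher number from compound 1 to compound 2 (0.04 log units; within the scatter), so compounds 1 and 2 are indistinguishable. Compound 3 `CC1CCN(Cc2ccc3nc(NC(=O)N/N=C/c4c[nH]c5ccccc45)sc3c2)CC1` differs from compound 2 by hydrogen in place of 2-chlorobenzyl on an aromatic nitrogen. Going by the values given here, the only measured step concerns the amine on the saturated chain carbon, not the aromatic nitrogen, so no measured step bears on this change. With nothing to anchor it, the step is expected to be modest and toward a higher number, a 2.3-fold higher number from compound 2 to compound 3 (0.36 log units; beyond the scatter). Compound 3 is therefore estimated at 2500 nM, within 900 nM to 7000 nM.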

Compound 3, half-maximal inhibitory concentration: 4130 nM
Compound 3: the middle estimate sits 1.7-fold (0.22 log units) below what was measured; the measured number falls inside the stated range.
By their numbers in this assay, from the lowest: compounds 1 and 2 (each within the scatter of the next); then compound 3.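

Hydrogen in place of 2-chlorobenzyl on the aromatic nitrogen gives a 3.8-fold higher number from compound 2 to compound 3 (0.58 log units; beyond the scatter) in this assay, so this position, unlike the amine on the saturated chain carbon, moves the number beyond the scatter. Inhibition weakens on this change but is not lost, since compound 3 still gives a measured number. No evidence on hand accounts for this step.

On these data alone, whether methyl or unsubstituted benzyl on that nitrogen would keep the lower number remains open. So does whether the step holds with diethylamino on the chain carbon.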